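The compounds below may be only part of what the source reports. "The series", "measured", "known", "first", "only" and "open" are said of these compounds alone.

Working notes on the series, read in a functional assay on A-375 cells (Homo sapiens) for antiproliferative activity; a lower number here means a stronger inhibitor, a higher number a weaker inhibitor. Compound 1 `O=C(Nc1ccc(-c2cscn2)cc1)C1CCCN(Cc2ccc(F)c(F)c2)C1` gives 880 nM, compound 2 `O=C(Nc1ccc(-c2ccccc2)cc1)C1CCCN(Cc2ccc(F)c(F)c2)C1` gives 2580 nM, and compound 3 `O=C(Nc1ccc(-c2ccccn2)cc1)C1CCCN(Cc2ccc(F)c(F)c2)C1` gives 9000 nM, the highest number of the three. Compound 4 `O=C(Nc1ccc(-c2ccn[nH]2)cc1)C1CCCN(Cc2ccc(F)c(F)c2)C1` has 1H-pyrazol-5-yl in place of pyridin-2-yl on an aromatic carbon.

All three measured steps change this same group. The modest ones are a 2.9-fold higher number from compound 1 to compound 2 (0.47 log units; beyond the scatter) and a 3.5-fold higher number from compound 2 to compound 3 (0.54 log units; beyond the scatter), while the large one is a 10-fold higher number from compound 1 to compound 3 (1.01 log units; beyond the scatter). Among the compounds with values here, this large step bears most directly, since compound 1 is the only measured compound with a five-membered aromatic ring there. Within the data shown here, none of the measured groups has a hydrogen-bond donor, so that part of the change has no precedent, and the full size of the large step is not assumed. A modest to large fall in this assay is expected. The expected change is a 4.1-fold lower number from compound 3 to compound 4 (0.61 log units; beyond the scatter). For compound 4 the estimated value is 2200 nM, with an expected range of 600 nM to 8000 nM.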

Compound 4, half-maximal inhibitory concentration: 520 nM
The estimate for compound 4 lay 4.2-fold (0.63 log units) above the measured number; measured number below the stated range.
By their numbers in this assay, from the lowest: compounds 4 and 1 (each within the scatter of the next); then compound 2; then compound 3.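

In this assay, 1H-pyrazol-5-yl gives a 17-fold lower number from compound 3 to compound 4 (1.24 log units; beyond the scatter) and a 5.0-fold lower number from compound 2 to compound 4 (0.70 log units; beyond the scatter), which extends to a second five-membered aromatic ring the advantage over phenyl and pyridin-2-yl that previously rested on compound 1 alone, and none of the four compounds goes against this pattern. With a 1.7-fold lower number from compound 1 to compound 4 (0.23 log units; within the scatter), 1H-pyrazol-5-yl and 1,3-thiazol-4-yl cannot be told apart here, so a hydrogen-bond donor at this position is tolerated but shows no gain over a group without one. Nothing available explains these differences.

Going by these compounds, it remains open whether ring size or the hetero atoms account for the pattern. A 1-methyl-1H-pyrazol-5-yl or furan-2-yl group would test this, and an amine or carboxylic acid on the same aromatic carbon would test how far the position extends beyond aromatic rings.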